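Truncating the aryl on the ring carbon of compound 1

The compounds below may be only part of what the source reports. "The series", "measured", "known", "first", "only" and "open" are said of these compounds alone.

Compound 1 `O=C(Nc1ccc(F)cc1)N1N=C(c2ccc(Br)cc2)CC1c1ccc(F)cc1` and compound 2 `O=C(Nc1ccccn1)N1N=C(c2ccc(Br)cc2)CC1c1ccc(F)cc1` share one core and differ only in the group on the urea nitrogen. In an assay on HEK293 cells for inhibition of Voltage-dependent L-type calcium channel subunit alpha-1C (Homo sapiens), read by FLIPR and calcium flux, with a stated time of 3 min (on this read-out higher numbers stand for weaker inhibition and lower numbers for stronger inhibition), compound 1 gives > 10000 nM, which is a limit of the assay and not a number. Where compound 1 stands is therefore known from the limit of > 10000 nM in this assay, at which 1 of the 2 values shown sits, alone. Compound 2 gives 2180 nM in this assay. For the measured compounds named here, the only measured step, an at least 4.5-fold lower number from compound 1 to compound 2 (0.66 log units; beyond the scatter), sits at a different place from the change considered here. Compound 3 `CC1=NN(C(=O)Nc2ccc(F)cc2)C(c2ccc(F)cc2)C1` differs from compound 1 by methyl in place of 4-bromophenyl on a carbon with a double bond to nitrogen. Going by the values given here, no measured step touches this position, so nothing beyond the limit of compound 1 informs the expectation. Compound 1 already sits at the limit. What is expected is a step that the limit leaves unreadable from compound 1 to compound 3, toward weaker inhibition or none beyond the scatter. Compound 3 is estimated at 20000 nM, between 8000 nM and 60000 nM, most likely reported again as a limit.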

Compound 3, half-maximal inhibitory concentration: > 10000 nM
Compound 3: a limit, no number; the forecaster's own chance of this, stated with the estimate: 80%; the middle value does not contradict the limit.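

No step from compound 1 to compound 3 can be read, since both values are limits of the assay and not numbers: the limit of > 10000 nM in this assay, at which 2 of the 3 values shown sit.

From the compounds shown here alone, whether methyl in place of 4-bromophenyl changes inhibition at all stays open, as does how that change would read alongside the pyridin-2-yl group of compound 2.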